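Furan-2-yl in place of 2-methylphenyl: working notes

The source may report more compounds than this note shows. Statements on the series, on what has been measured and on what is new or still open speak of the compounds shown alone.

In a functional assay on 1A9 cells (Homo sapiens) for cytotoxicity (a higher number here means that more compound is needed for the effect, a lower number that less compound is needed), compound 1 (`COC1=C(C)C(=O)/C(=C(O)/C=C/c2cccc(OC)c2)C(=O)C1(C)C`) gives 2.9 ug/mL and compound 2 (`COC1=C(C)C(=O)/C(=C(O)/C=C/c2ccccc2OC)C(=O)C1(C)C`) gives 2.5 ug/mL as read-outs. Compound 3 (`COC1=C(C)C(=O)/C(=C(O)/C=C/c2ccccc2C)C(=O)C1(C)C`) has no number to start from: its entry reads "not determined" (no result reported) and offers no anchor. The change to compound 4 (`COC1=C(C)C(=O)/C(=C(O)/C=C/c2ccco2)C(=O)C1(C)C`) is furan-2-yl in place of 2-methylphenyl on a double-bonded chain carbon bound to a double-bonded chain carbon (furan-2-yl in place of 2-methylphenyl). Going by the values given here, the only measured step is a 1.2-fold lower number from compound 1 to compound 2 (0.06 log units; within the scatter) and it moves a methoxy group without replacing the ring, so it bears only loosely on this change. No size or direction can be set for a step from compound 3. The expectation therefore rests on compound 1 (2.9 ug/mL) and compound 2 (2.5 ug/mL), with nothing expected beyond the scatter of those values. Compound 4 is estimated at 3 ug/mL (expected range 1.2 ug/mL to 7.5 ug/mL).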

Compound 4, concentration for half-maximal effect: 7.9 ug/mL
Compound 4: the middle estimate sits 2.6-fold (0.42 log units) below what was measured; measured number above the stated range.
By their numbers in this assay, from the lowest: compounds 2 and 1 (each within the scatter of the next); then compound 4.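

In this assay, the ring at this place on the chain proves able to move the read-out beyond the scatter: a 3.2-fold higher number from compound 2 to compound 4 (0.50 log units; beyond the scatter) and a 2.7-fold higher number from compound 1 to compound 4 (0.44 log units; beyond the scatter) with furan-2-yl in place of a methoxyphenyl ring. Moving the methoxy group between compound 1 and compound 2 showed no such shift, so among these compounds the change of ring counts for more than the methoxy placement. No measured data explain the rise. Steps from compound 3 cannot be read, since it has no number. Open, from the compounds shown here alone, is whether unsubstituted phenyl or thiophen-2-yl at this place would follow furan-2-yl or the methoxyphenyl rings.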